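The source may hold more compounds than are shown below. What is called first, only, known or untested is meant among the compounds shown, and "the series" means these compounds.

Working notes on the series. Compound 1 `COc1ccc(/C=C2\CN(C(=S)SCc3cn(Cc4ccccc4F)nn3)C/C(=C\c3ccc(OC)cc3)C2=O)cc1` and compound 2 `COc1ccc(/C=C2\CN(C(=S)SCc3cn(Cc4ccc(F)cc4)nn3)C/C(=C\c3ccc(OC)cc3)C2=O)cc1` share one core, while compound 3 `O=C1/C(=C/c2ccccc2F)CN(C(=S)SCc2cn(Cc3ccccc3F)nn2)C/C1=C\c1ccccc1F` and compound 4 `O=C1/C(=C/c2ccccc2F)CN(C(=S)SCc2cn(Cc3ccc(F)cc3)nn2)C/C1=C\c1ccccc1F` share another, and the difference between the two cores is not broken down here. In a functional assay on PC-3 cells (Homo sapiens) for cytotoxicity, read by MTT assay, with a stated time of 24 h (a lower number here means a stronger inhibitor, a higher number a weaker inhibitor), compound 1 gives 31500 nM. In this assay compound 2 gives 45600 nM. The change between them is 4-fluorophenyl in place of 2-fluorophenyl on a saturated chain carbon bound to an aromatic nitrogen, and it made the step of a 1.4-fold higher number from compound 1 to compound 2 (0.16 log units; within the scatter). For compound 3, this assay reports only a limit, > 80000 nM. That value is the limit of > 80000 nM in this assay, at which 1 of the 3 values shown sits.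

The change from compound 3 to compound 4 is the same one: 4-fluorophenyl in place of 2-fluorophenyl on a saturated chain carbon bound to an aromatic nitrogen, at the same place on a saturated chain carbon bound to an aromatic nitrogen, with the outer reading 2-fluorobenzyl to 4-fluorobenzyl. On the first core this change stayed within the scatter, so on the second core a step of the same small size is the expectation, and the estimate for the step from compound 3 to compound 4 is a step that the limit leaves unreadable from compound 3 to compound 4. This rests on the measured step of a 1.4-fold higher number from compound 1 to compound 2 (0.16 log units; within the scatter). It also rests on compound 3 standing at a limit, > 80000 nM, from which a small step cannot bring the number down into the measured range. Compound 4 is therefore expected to give 110000 nM in this assay, and most likely to be reported again only as a limit. For compound 4 the expected range is taken to run from 60000 nM to 250000 nM.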

Compound 4, half-maximal inhibitory concentration: > 80000 nM
Compound 4: only a limit was reported (the forecaster's own chance of this, stated with the estimate: 75%); the middle value lies beyond the limit too.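

In this assay compound 4 gives only a limit, > 80000 nM, and compound 3 is likewise reported only as a limit, so no step can be read between compound 3 and compound 4: the limit of > 80000 nM in this assay, at which 2 of the 4 values shown sit.

The compounds shown leave open where the true numbers of compound 3 and compound 4 lie, and whether the change from 2-fluorobenzyl to 4-fluorobenzyl moves the number on their shared core at all.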